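Phenoxy variation on a benzothiazole hydrazone core

The compounds below may be only part of what the source reports. "The series", "measured", "known", "first", "only" and "open" are said of these compounds alone.

Measured so far:
compound 1 `O=C(CSc1nc2ccccc2s1)N/N=C/c1ccc(Oc2ccccc2)cc1` gives 5.6
compound 2 `O=[N+]([O-])c1ccc(Oc2ccc(/C=N/Nc3nc4ccccc4s3)cc2)cc1` gives 5.1
compound 3 `Cc1cc(Oc2ccc(/C=N/Nc3nc4ccccc4s3)cc2)ccc1Cl` gives 5.5

In a physicochemical assay for lipophilicity, in phosphate buffer, measured as octanol-water partition, with a stated time of 24 h (on this read-out lower numbers stand for lower lipophilicity and higher numbers for higher lipophilicity), compound 3 stands second highest of the three: compound 1 lies close to it, within the scatter, while compound 2 sits lower, beyond it. Within the data shown here, the one comparable step, a number 0.40 log units higher from compound 2 to compound 3 (beyond the scatter), shows that changing the group on the oxygen on an aromatic ring shifts this assay modestly. Compound 4 `C(=N/Nc1nc2ccccc2s1)\c1ccc(Oc2ccccc2)cc1` carries phenyl in place of 4-chloro-3-methylphenyl on an oxygen on an aromatic ring. Among the measured compounds shown here, no measured pair shows exactly this change, so the expectation rests on the modest size of that step. The estimated shift is a number 0.60 log units lower from compound 3 to compound 4 (beyond the scatter), a downward move. Compound 4 is therefore expected to give about 4.9, between 4.4 and 5.4.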

Compound 4, partition coefficient: 5.2
Beside the measured number, compound 4's estimate is 0.30 log units below it; low and high end bracket the measured number.
By their numbers in this assay, from the lowest: compounds 2, 4, 3 and 1 (each within the scatter of the next, the first and the last beyond it).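

In this assay, plain phenyl on the oxygen cannot be told apart from either substituted ring: replacing 4-chloro-3-methylphenyl leaves the reading within the scatter (a number 0.30 log units lower from compound 3 to compound 4 (within the scatter)), and so does hydrogen in place of nitro (a number 0.10 log units higher from compound 2 to compound 4 (within the scatter)). The gap beyond the scatter therefore appears only between the two substituted rings, with the unsubstituted ring lying within the scatter of both. From the compounds shown here alone, whether an amine or a carboxylic acid on this ring would shift the number beyond the scatter from compound 4 stays open. Nothing available explains the size of these steps.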